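A few compounds are considered here, and "the series" means these few. Any claim that something is new, unique, unknown or untested is made for them only; others in the source may bear on it.

In a functional assay on Huh-7 cells (Homo sapiens) for cytotoxicity, read by MTT assay, with a stated time of 3 days (a higher number here means that more compound is tolerated, a lower number that less compound is tolerated), compound 3 `OC[C@H]1O[C@@H](n2cnc3c(CSc4nc5ccccc5s4)ncnc32)[C@H](O)[C@@H]1O` gives > 100000 nM as its reading, which is a limit of the assay and not a number. Compound 1 `O=c1ccn(Cc2ncnc3c2ncn3[C@@H]2O[C@H](CO)[C@@H](O)[C@H]2O)cc1` gives > 100000 nM as its reading, and that too is only a limit. Compound 2 `O=C1CCCN1Cc1ncnc2c1ncn2[C@@H]1O[C@H](CO)[C@@H](O)[C@H]1O` gives 45000 nM as a true number. Compound 3 therefore stands at the limit of > 100000 nM in this assay, at which 2 of the 3 values shown sit, and nothing more exact is known of it.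

Compound 4 `O=C(O)CSCc1ncnc2c1ncn2[C@@H]1O[C@H](CO)[C@@H](O)[C@H]1O` differs from compound 3 in one group: carboxymethyl in place of 1,3-benzothiazol-2-yl on a sulfur and so carboxymethyl takes the place of 1,3-benzothiazol-2-yl on a sulfur, with no ring in the new group. Within the data shown here, the only measured step to lean on is an at least 2.2-fold lower number from compound 1 to compound 2 (0.34 log units; beyond the scatter) and it concerns another swap, on a saturated chain carbon rather than on a sulfur, so it is a loose guide. Still, it was a modest move. Read against compound 2 at 45000 nM and that modest step, compound 4 is expected to stay near the top of the measured range, with no sharp fall. The estimated move is a number no higher from compound 3 to compound 4 (the limit leaves the size open) and no change beyond the scatter is expected. The estimated value for compound 4 is 100000 nM within an expected range from 40000 nM to 250000 nM and the reading may again be only a limit.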

Compound 4, half-maximal cytotoxic concentration: > 100000 nM
Compound 4 gave a limit, no number; the forecaster's own chance of this, stated with the estimate: 70%; the middle value sits exactly at the limit.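

On the sulfur, carboxymethyl, with no ring, and 1,3-benzothiazol-2-yl, with one five-membered and one six-membered aromatic ring, both give readings in this assay that are limits and not numbers, so rings on this sulfur are not needed for a compound to reach that limit. The steps to compound 4 from compound 3 and from compound 1 cannot be read, as both ends of each are limits. The one readable step, an at least 2.2-fold higher number from compound 2 to compound 4 (0.34 log units; beyond the scatter), puts (carboxymethyl)sulfanyl in place of 2-oxopyrrolidin-1-yl on a saturated chain carbon bound to an aromatic carbon, which leaves 2-oxopyrrolidin-1-yl as the only group here that brings a true number: the limit of > 100000 nM in this assay, at which 3 of the 4 values shown sit.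

Going by these compounds, how far compound 1, compound 3 and compound 4 lie beyond the limit stays unknown, so any real difference among them is hidden. Also open, on these data alone, is whether an amine or a longer chain on the sulfur would stay at the limit or drop to a true number. Compound 2 gives such a true number, 45000 nM.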